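This account rests on a few compounds, and the source may have more. Where it says the series, first, only, none or still open, it means among the compounds named here.

In an ADME assay on MT4 cells (Homo sapiens) for cytotoxicity, read by MTT assay (on this read-out lower numbers stand for higher toxicity in this test and higher numbers for lower toxicity in this test), compound 1 `COC(=O)c1ccc(NC(=O)CSc2nncnc2-c2ccccc2Cl)c(Br)c1` gives 59000 nM, compound 2 `Cc1ccc(NC(=O)CSc2nncnc2-c2cccc3ccccc23)c(Br)c1` gives 166000 nM, and compound 3 `Cc1ccccc1NC(=O)CSc1nncnc1-c1cccc2ccccc12` gives 158000 nM. Compound 3 thus holds the second highest of the three numbers in this assay; its value and that of compound 2 lie within the scatter of each other, while compound 1 stands beyond the scatter at a lower number. Compound 4 `O=C(CSc1nncnc1-c1cccc2ccccc12)Nc1ccccc1` differs from compound 3 by hydrogen in place of methyl on an aromatic carbon. For the measured compounds named here, the only measured step that bears on this part of the molecule is a 1.1-fold lower number from compound 2 to compound 3 (0.02 log units; within the scatter), and it stayed within the scatter. A single small change of this kind is therefore expected to shift this assay by no more than the scatter, and the step is estimated as a 1.1-fold lower number from compound 3 to compound 4 (0.02 log units; within the scatter). Compound 4 is expected to give about 150000 nM in this assay, with a range from 75000 nM to 300000 nM.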

Compound 4, half-maximal cytotoxic concentration: 154000 nM
Estimate against measurement, compound 4: 1.0-fold (0.01 log units) below, and the stated range covers the measured number.
By their numbers in this assay, from the lowest: compound 1; then compounds 4, 3 and 2 (each within the scatter of the next).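

In this assay the methyl on this aromatic carbon gives way to hydrogen with a 1.0-fold lower number from compound 3 to compound 4 (0.01 log units; within the scatter). Phenyl in place of 2-bromo-4-methylphenyl on the amide-type nitrogen gives a 1.1-fold lower number from compound 2 to compound 4 (0.03 log units; within the scatter), so with this shared core neither change moves the number beyond the scatter. No evidence is available to explain this result. The compounds shown leave open whether an amine or a carboxylic acid on this aromatic carbon would move the number beyond the scatter. They also leave open whether a longer chain there would do so.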